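The source may hold more compounds than are shown below. What is called first, only, known or untested is meant among the compounds shown, and "the series" means these compounds.

Measured compounds:
- Compound 1 `Oc1ccc(-c2cc(-c3cccs3)nc(-c3ccccc3Cl)c2)cc1`: in an assay on isolated protein for inhibition of DNA topoisomerase 1 (Homo sapiens), with a stated time of 30 min, tested at 100 uM (on this read-out higher numbers stand for a stronger effect at the one concentration tested and lower numbers for a weaker effect), compound 1 gives 2.2%.
- Compound 2 `Oc1cccc(-c2cc(-c3ccsc3)nc(-c3ccccc3Cl)c2)c1`: compound 2 gives 0%.
- Compound 3 `Oc1ccc(-c2cc(-c3ccccn3)nc(-c3ccccc3Cl)c2)cc1`: compound 3 gives 5.2%.

Compound 3 holds the highest of the three numbers, yet compound 1 and compound 2 both sit within the scatter of it, so the three are not separated on these data. The change under consideration is thiophen-3-yl in place of pyridin-2-yl on an aromatic carbon, which yields compound 4 `Oc1ccc(-c2cc(-c3ccsc3)nc(-c3ccccc3Cl)c2)cc1`. Within the data shown here, one measured step touches the same place: a number 3 percentage points higher from compound 1 to compound 3 (within the scatter), where a five-membered aromatic ring with one hetero atom was exchanged for the six-membered one and the number stayed within the scatter. Among the measured compounds shown here, compound 2 carries thiophen-3-yl as well, though it differs from compound 3 elsewhere too; its value and that of compound 3 lie within the scatter of each other, so no step is drawn from that pair. Taken together, the expectation in this assay is a step of no size beyond the scatter, a number 3.2 percentage points lower from compound 3 to compound 4 (within the scatter) being what is expected. Compound 4 is estimated at 2%, with a range from 0% to 8%.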

Compound 4, a percentage reported as inhibition, at one concentration (the size of the read-out at that concentration, not a potency): 4.1%
Beside the measured number, compound 4's estimate is 2.1 percentage points below it; the range from low to high includes it.
By their numbers in this assay, from the lowest: compounds 2, 1, 4 and 3 (each within the scatter of the next).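

In this assay, thiophen-3-yl in place of pyridin-2-yl on the aromatic carbon next to the ring nitrogen gives a number 1.1 percentage points lower from compound 3 to compound 4 (within the scatter) and thus leaves a five-membered aromatic ring with sulfur and a six-membered aromatic ring with nitrogen unseparated at this position. Moving the attachment point of the thiophene also separates nothing, with a number 1.9 percentage points higher from compound 1 to compound 4 (within the scatter) for thiophen-3-yl in place of thiophen-2-yl, and the matched change on the other aryl group, 4-hydroxyphenyl in place of 3-hydroxyphenyl, gives a number 4.1 percentage points higher from compound 2 to compound 4 (within the scatter) as a first reading of that place. No measurement is available that bears on these results.

Going by these compounds, whether an aminomethyl group, a carboxylic acid or a longer alkyl chain at this position would move the read-out beyond the scatter remains open. Also open, on these data alone, is whether replacing the 2-chlorophenyl group would separate any compounds in this assay at all.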